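The source may report more compounds than this note shows. Statements on the series, on what has been measured and on what is new or still open speak of the compounds shown alone.

Measured compounds:
compound 1, `CCCCCc1nc(C(F)(F)F)ccc1CNC(=O)C(C)c1ccc(NS(C)(=O)=O)c(F)c1`: 1 nM
compound 2, `CC(C(=O)NCc1ccc(C(F)(F)F)nc1C1CC2CCC1C2)c1ccc(NS(C)(=O)=O)c(F)c1`: 1.5 nM

Both values come from an assay on CHO cells for antagonist activity at transient receptor potential cation channel subfamily V member 1 (Homo sapiens), read by FLIPR and calcium flux; a higher number here means a weaker inhibitor, a lower number a stronger inhibitor. Compound 1 gives the lowest of the two numbers in this assay, and its nearest neighbour is compound 2, with the step of a 1.5-fold higher number from compound 1 to compound 2 (0.18 log units; within the scatter). That step swaps the pentyl chain on an aromatic carbon for a bicyclic group, and the number barely moves.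

Compound 3, `CC(C(=O)NCc1ccc(C(F)(F)F)nc1C1=CCC(C)(C)CC1)c1ccc(NS(C)(=O)=O)c(F)c1`, has not yet been measured. It differs from compound 1 in one place: 4,4-dimethylcyclohex-1-en-1-yl in place of pentyl on an aromatic carbon. For the measured compounds named here, the only measured step that bears on this change is the one from compound 1 to compound 2, which exchanges the same pentyl chain for another ring-containing carbon group and stays within the scatter. A step of similar size, or none beyond the scatter, is therefore expected here, with a slight lean toward a higher number, as a 1.5-fold higher number from compound 1 to compound 3 (0.18 log units; within the scatter) expresses. Compound 3 is estimated at 1.5 nM, with a range of 0.5 nM to 5 nM.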

Compound 3, inhibition constant: 0.2 nM
The estimate for compound 3 lay 7.5-fold (0.88 log units) above the measured number; measured number below the stated range.
By their numbers in this assay, from the lowest: compound 3; then compounds 1 and 2 (each within the scatter of the next).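

In this assay, this position next to the ring nitrogen proves able to move the number beyond the scatter: 4,4-dimethylcyclohex-1-en-1-yl in place of pentyl gives a 5.0-fold lower number from compound 1 to compound 3 (0.70 log units; beyond the scatter), a stronger inhibitor, whereas the earlier pair showed no such change. A ring alone does not account for this, since the two ring-bearing groups also differ clearly, with a 7.5-fold lower number from compound 2 to compound 3 (0.88 log units; beyond the scatter), and compound 3 comes out as the strongest inhibitor of the three. Nothing available explains why this group gives the stronger inhibition.

The compounds shown leave open which feature of the group matters, the double bond or the two methyl groups, as a plain cyclohexyl group would help to separate them. They also leave open how this position responds to groups containing atoms other than carbon, such as an amine or a morpholine ring.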